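Aryl exchange on the sulfonamide and HEK293 tolerance

The source may report more compounds than this note shows. Statements on the series, on what has been measured and on what is new or still open speak of the compounds shown alone.

Compound 1, `COc1ccc(Cl)cc1S(=O)(=O)Nc1ccc(-c2nc3ccccc3o2)cc1`: in an ADME assay on HEK293 cells (Homo sapiens) for cytotoxicity, read by resazurin assay, with a stated time of 48 h (a higher number here means that more compound is tolerated, a lower number that less compound is tolerated), compound 1 gives 75000 nM.
Compound 2, `Cc1cccc(S(=O)(=O)Nc2ccc(-c3nc4ccccc4o3)cc2)c1`: in this assay compound 2 reaches only a limit of the assay, > 100000 nM.
Compound 3, `CCc1ccc(S(=O)(=O)Nc2ccc(-c3nc4ccccc4o3)cc2)cc1`: in this assay compound 3 gives 82000 nM.

Going by the values given here, compound 3 stands highest of the two numbers given, with compound 1 as its nearest neighbour; the step of a 1.1-fold higher number from compound 1 to compound 3 (0.04 log units; within the scatter) lies within the scatter, and the one further value given for this series is a limit, (the limit of > 100000 nM in this assay, at which 1 of the 3 values shown sits). The unmeasured compound 4, `COc1cccc(S(=O)(=O)Nc2ccc(-c3nc4ccccc4o3)cc2)c1`, differs from compound 3 in one place: 3-methoxyphenyl in place of 4-ethylphenyl on a sulfonyl sulfur. Among the compounds with values here, three measured steps bear on this change, since each of them also exchanges the aryl group on the sulfonyl sulfur: an at least 1.3-fold higher number from compound 1 to compound 2 (0.12 log units; that floor lies within the scatter), a 1.1-fold higher number from compound 1 to compound 3 (0.04 log units; within the scatter) and an at least 1.2-fold lower number from compound 2 to compound 3 (0.08 log units; that floor lies within the scatter). None of them rises beyond the scatter, and the three groups tried so far, whether bearing chlorine and methoxy, a methyl or an ethyl, leave the tolerated concentration in the same region. For compound 4 the step of a 1.0-fold higher number from compound 3 to compound 4 (0.02 log units; within the scatter) is therefore expected to stay within the scatter. Compound 4 is estimated at 85000 nM, with a likely range from 50000 nM to 130000 nM, and a fair chance that this assay reports only its limit again.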

Compound 4, half-maximal cytotoxic concentration: > 100000 nM
Compound 4: a limit, no number; the forecaster's own chance of this, stated with the estimate: 35%; middle value at least 1.1-fold (0.07 log units) away from the limit.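

Exchanging 4-ethylphenyl for 3-methoxyphenyl on the sulfonyl sulfur adds one hydrogen-bond acceptor to the aryl group and gives an at least 1.2-fold higher number from compound 3 to compound 4 (0.08 log units; that floor lies within the scatter), while the exchange from the chlorine-bearing group gives an at least 1.3-fold higher number from compound 1 to compound 4 (0.12 log units; that floor lies within the scatter), so neither step establishes a real gain in tolerance in this assay. What this result adds is that an aryl group bearing a single methoxy, like the 3-methylphenyl group of compound 2, leaves the reading at a limit, so this position has now accepted an oxygen-bearing substituent without any step beyond the scatter. The step between compound 2 and compound 4 cannot be read, and the exchange of methyl for methoxy therefore has no size here, as both compounds stand at a limit: the limit of > 100000 nM in this assay, at which 2 of the 4 values shown sit.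

On these data alone, how far the true values of compound 2 and compound 4 lie past that limit remains open. Also open, as far as these compounds go, is whether a carboxylic acid or an amine on this aryl group, or a longer chain in place of the ethyl, would move the tolerated concentration beyond the scatter.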